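The source may report more compounds than this note shows. Statements on the series, on what has been measured and on what is new or still open speak of the compounds shown alone.

Compound 3 `O=C(O)CCCSCCN1C(=O)SC[C@@H]1/C=C/[C@@H](O)Cc1cccc(C(F)(F)F)c1` stands at the low end of the three numbers recorded in a functional assay on CHO cells for agonist activity at prostaglandin E2 receptor EP4 subtype (Rattus norvegicus), read by cAMP accumulation and immunoassay, with a stated time of 10 min (on this read-out higher numbers stand for an effect only at larger amounts of compound and lower numbers for an effect already at smaller amounts), where compound 3 gives 4.3 nM. Compound 1 `O=C(O)CCCSCCN1C(=O)SC[C@@H]1/C=C/[C@@H](O)Cc1ccccc1` gives 4.8 nM and compound 2 `CCCc1cccc(C[C@H](O)/C=C/[C@H]2CSC(=O)N2CCSCCCC(=O)O)c1` gives 6.1 nM; the steps of a 1.1-fold lower number from compound 1 to compound 3 (0.05 log units; within the scatter) and a 1.4-fold lower number from compound 2 to compound 3 (0.15 log units; within the scatter) both lie within the scatter. Compound 4 `COCc1cccc(C[C@H](O)/C=C/[C@H]2CSC(=O)N2CCSCCCC(=O)O)c1` differs from compound 3 by methoxymethyl in place of trifluoromethyl on an aromatic carbon. Going by the values given here, the steps that bear on this position are a 1.3-fold higher number from compound 1 to compound 2 (0.10 log units; within the scatter), a 1.1-fold lower number from compound 1 to compound 3 (0.05 log units; within the scatter) and a 1.4-fold lower number from compound 2 to compound 3 (0.15 log units; within the scatter), none of them beyond the scatter, so no step beyond the scatter is expected in this assay either, in either direction. Compound 4 is therefore estimated at 5.5 nM, between 2.2 nM and 14 nM, an expected step of a 1.3-fold higher number from compound 3 to compound 4 (0.11 log units; within the scatter).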

Compound 4, half-maximal effective concentration: 2.4 nM
Compound 4: middle estimate off by 2.3-fold (0.36 log units), on the high side; the measured number falls inside the stated range.
By their numbers in this assay, from the lowest: compounds 4, 3, 1 and 2 (each within the scatter of the next, the first and the last beyond it).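

In this assay, methoxymethyl on this aromatic carbon gives the only step beyond the scatter among the compounds shown (the modest 2.5-fold lower number from compound 2 to compound 4 (0.41 log units; beyond the scatter)), while the same group stays within the scatter against trifluoromethyl (a 1.8-fold lower number from compound 3 to compound 4 (0.25 log units; within the scatter)) and against hydrogen (a 2.0-fold lower number from compound 1 to compound 4 (0.30 log units; within the scatter)). The position thus accepts a group with a hydrogen-bond acceptor without any loss, and the order of the propyl and methoxymethyl compounds is now resolved. Nothing measured here explains this step. Still open, as far as these compounds go, is how an amine or a carboxylic acid on this aromatic carbon would read.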